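The source may hold more compounds than are shown below. What is called first, only, known or untested is meant among the compounds shown, and "the series" means these compounds.

The series shares the core of compound 1 `O=C(Nc1cccnc1)c1ccccc1OCc1ccccc1`, which in an assay on lysate for inhibition of phosphatidylcholine:ceramide cholinephosphotransferase 2 (Homo sapiens), read by HPLC, with stated times of 30 min and 2 h (on this read-out lower numbers stand for stronger inhibition and higher numbers for weaker inhibition), gives 3200 nM. Compound 2 `Cc1ccccc1COc1ccccc1C(=O)Nc1cccnc1` gives 1500 nM, and compound 3 `O=C(Nc1cccnc1)c1ccccc1OCc1ccccc1C(F)(F)F` gives 2100 nM; compound 3 thus holds the second highest of the three numbers, its nearest neighbour being compound 2 and its furthest compound 1, both within the scatter. Compound 4 `O=C(Nc1cccnc1)c1ccccc1OCc1ccccc1OCCCCCCl` carries (5-chloropentyl)oxy in place of trifluoromethyl on an aromatic carbon, on an aromatic carbon of a six-membered aromatic ring of carbon only, ortho to a large group. The steps bearing on this position are a 2.1-fold lower number from compound 1 to compound 2 (0.33 log units; beyond the scatter), a 1.5-fold lower number from compound 1 to compound 3 (0.18 log units; within the scatter) and a 1.4-fold higher number from compound 2 to compound 3 (0.15 log units; within the scatter); all are modest or within the scatter, so in this assay a step of a 1.2-fold lower number from compound 3 to compound 4 (0.07 log units; within the scatter) is expected, nothing beyond the scatter. Compound 4 is therefore estimated at 1800 nM, range 700 nM to 5000 nM.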

Compound 4, half-maximal inhibitory concentration: 670 nM
Beside the measured number, compound 4's estimate is 2.7-fold (0.43 log units) above it; the measured number lies below the stated range.
By their numbers in this assay, from the lowest: compound 4; then compounds 2, 3 and 1 (each within the scatter of the next, the first and the last beyond it).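

In this assay, the position on the aromatic carbon ortho to a large group accepts (5-chloropentyl)oxy, with steps to it from all three earlier compounds lying beyond the scatter (a 3.1-fold lower number from compound 3 to compound 4 (0.50 log units; beyond the scatter); a 2.2-fold lower number from compound 2 to compound 4 (0.35 log units; beyond the scatter); a 4.8-fold lower number from compound 1 to compound 4 (0.68 log units; beyond the scatter)). Compound 4 is thus the first compound separated beyond the scatter from every other, and the strongest of the four. Nothing available accounts for this gain. The compounds shown do not separate the contributions of the oxygen, the pentyl chain and the chlorine. Methoxy, an unchlorinated pentyloxy or an amine in place of the chlorine would bear on that.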